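Bromocatechols: Swapping Formyl for Ethoxymethyl in Cytotoxicity

The source may report more compounds than this note shows. Statements on the series, on what has been measured and on what is new or still open speak of the compounds shown alone.

Measured compounds:
compound 1, `CCCOCc1cc(O)c(O)c(Br)c1Br`: 12400 nM
compound 2, `O=Cc1cc(O)c(O)c(Br)c1Br`: 30900 nM
compound 3, `O=Cc1cc(Br)c(O)c(O)c1Br`: 31000 nM

Three brominated catechols have been tested in a functional assay on DLD-1 cells (Homo sapiens) for cytotoxicity, read by MTT assay, with a stated time of 96 h; a higher number here means a weaker inhibitor, a lower number a stronger inhibitor. Compound 1 carries a propoxymethyl group and gives the lowest of the three numbers. Compound 2 and compound 3 each carry a formyl group, and their numbers lie within the scatter of one another; compound 3 gives the highest number of the three, while standing well apart from compound 1.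

Compound 4, `CCOCc1cc(Br)c(O)c(O)c1Br`, has not yet been measured in this assay. It differs from compound 3 by ethoxymethyl in place of formyl on an aromatic carbon.

Among the measured compounds shown here, the one measured step that bears on this change is a 2.5-fold higher number from compound 1 to compound 2 (0.40 log units; beyond the scatter), where an alkoxymethyl group was exchanged for formyl. The step from compound 3 to compound 4 runs the other way, formyl to alkoxymethyl, so a lower number of roughly that size is expected. Given that compound 3 gives 31000 nM, compound 4 is estimated at 14000 nM, with a range of 7000 nM to 28000 nM, meaning an expected step of a 2.2-fold lower number from compound 3 to compound 4 (0.35 log units; beyond the scatter).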

Compound 4, half-maximal inhibitory concentration: 7150 nM
Estimate against measurement, compound 4: 2.0-fold (0.29 log units) above; the measured number falls inside the stated range.
By their numbers in this assay, from the lowest: compounds 4 and 1 (each within the scatter of the next); then compounds 2 and 3 (each within the scatter of the next).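

In this assay, ethoxymethyl in place of formyl on the aromatic carbon ortho to a bromo group and para to a hydroxy group gives a 4.3-fold lower number from compound 3 to compound 4 (0.64 log units; beyond the scatter) and so moves compound 4 clearly away from its formyl partner. The earlier compounds shown here showed the formyl and alkoxymethyl exchange only on the core of compound 1, as a 2.5-fold higher number from compound 1 to compound 2 (0.40 log units; beyond the scatter) with propoxymethyl leaving, whereas the new pair shows the same direction on the core of compound 3 and with ethoxymethyl. No measurement shown here explains why the number falls.

The compounds shown leave open whether the ether oxygen of the alkoxymethyl group matters or the chain alone suffices, as a plain propyl group at this carbon could show. They also leave open how a carboxylic acid or an aminomethyl group would behave there.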